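The source may report more compounds than this note shows. Statements on the series, on what has been measured and on what is new or still open speak of the compounds shown alone.

Compound 1 `O=C1c2ccccc2CCCC1CCN1CCC(Oc2ccccc2)CC1`: 25.1 nM
Compound 2 `O=C1c2ccccc2CCCN1CCN1CCC(Oc2ccccc2)CC1`: 20.4 nM
Compound 3 `O=C1c2ccccc2CCCN1CCN1CCC(Oc2ccc(F)cc2)CC1`: 4.47 nM

All three were measured in an assay on isolated protein for binding affinity to 5-hydroxytryptamine receptor 7 (Homo sapiens); a higher number here means a weaker inhibitor, a lower number a stronger inhibitor. For the measured compounds named here, compound 2 gives the second highest of the three numbers; compound 1 sits within the scatter of it, while compound 3 lies beyond the scatter, and the step of a 4.6-fold lower number from compound 2 to compound 3 (0.66 log units; beyond the scatter) is the only one-place change recorded so far. Compound 4 `O=C1c2ccccc2CCCN1CCN1CCC(c2c[nH]c3ccccc23)CC1` differs from compound 2 by 1H-indol-3-yl in place of phenoxy on a saturated ring carbon. Going by the values given here, no measured step touches this change: the single recorded step swaps hydrogen for fluoro on an aromatic carbon and gives no guide to exchanging a phenoxy for an indolyl group. Among the compounds with values here, with no direct precedent, compound 4 is expected to stay near its parent, the expected step being a 1.4-fold lower number from compound 2 to compound 4 (0.13 log units; within the scatter) in this assay, and the estimate for compound 4 is 15 nM, in a range from 4 nM to 60 nM.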

Compound 4, inhibition constant: 0.407 nM
Compound 4: middle estimate off by 37-fold (1.57 log units), on the high side, outside the stated range (below it).
By their numbers in this assay, from the lowest: compound 4; then compound 3; then compounds 2 and 1 (each within the scatter of the next).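

In this assay the saturated ring carbon proves highly sensitive to what it carries: 1H-indol-3-yl in place of phenoxy gives a 50-fold lower number from compound 2 to compound 4 (1.70 log units; beyond the scatter) and in place of 4-fluorophenoxy gives an 11-fold lower number from compound 3 to compound 4 (1.04 log units; beyond the scatter) on the same core. Exchanging the whole group thus does more here than adding fluoro to the phenoxy ring, which gave a 4.6-fold lower number from compound 2 to compound 3 (0.66 log units; beyond the scatter) in the earlier step. Nothing measured here explains the size of this change.

The compounds shown leave open whether a plain phenyl or a benzimidazolyl group at this carbon would do the same. On these data alone, whether 1H-indol-3-yl acts alike on the core of compound 1 also stays open.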